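Phenyl for tert-butyl on the shared core

The compounds below may be only part of what the source reports. "The series", "measured", "known", "first", "only" and "open" are said of these compounds alone.

In an ADME assay on HEK293 cells (Homo sapiens) for cytotoxicity (a higher number here means that more compound is needed for the effect, a lower number that less compound is needed), compound 1 (`CC(C)(C)C1CNCCNCCNCCN1`) stands at > 200000 nM which is a limit and not a number. Compound 2 (`COc1ccc(C2CNCCNCCNCCN2)cc1`) gives > 200000 nM as a limit too. Compound 3 (`Brc1ccc(C2CNCCNCCNCCN2)cc1`) likewise gives > 200000 nM as a limit. Among the compounds with values here, the whole series so far sits at one ceiling (the limit of > 200000 nM in this assay, at which 3 of the 3 values shown sit) and compound 1 has no number to step from.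

Compound 4 (`c1ccc(C2CNCCNCCNCCN2)cc1`) differs from compound 1 by phenyl in place of tert-butyl on a saturated ring carbon on the core. Within the data shown here, the one measured step (a step that the two limits leave unreadable from compound 2 to compound 3) gives no size to carry over. The expected step (a number no higher from compound 1 to compound 4 (the limit leaves the size open)) is none beyond the scatter, with no direction favoured. For compound 4 the estimated value is 200000 nM with an expected range from 100000 nM to 400000 nM in this read-out.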

Compound 4, half-maximal effective concentration: > 200000 nM
Compound 4 ended at the assay's limit (the forecaster's own chance of this, stated with the estimate: 85%); the middle value sits exactly at the limit.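

Compound 1, compound 2, compound 3 and compound 4 all stand at a limit in this assay, so no step among them can be read: the limit of > 200000 nM in this assay, at which 4 of the 4 values shown sit.

The compounds shown leave open where any real value lies and whether tert-butyl, phenyl, methoxy or bromo shifts it.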